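A few compounds are considered here, and "the series" means these few. Any claim that something is new, unique, unknown or untested is made for them only; others in the source may bear on it.

Two thiocarbamate-bearing compounds sharing one core have been run in a functional assay on HeLa cells (Homo sapiens) for antiproliferative activity, read by MTT assay, with a stated time of 72 h; on this read-out lower numbers stand for stronger inhibition and higher numbers for weaker inhibition. Compound 1 `O=c1c(CSC(=S)N2CCOCC2)coc2cc(Cl)ccc12` gives 2000 nM in this assay. Going by the values given here, compound 2 `O=c1c(CSC(=S)N2CCCC2)coc2cc(Cl)ccc12` gives 1300 nM in this assay, and the change a 1.5-fold lower number from compound 1 to compound 2 (0.19 log units; within the scatter) is within the scatter, so the two compounds are indistinguishable on these numbers; compound 2 stands with compound 1 as its only neighbour and no other comparison.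

Compound 3 `CC(C)N(C(=S)SCc1coc2cc(Cl)ccc2c1=O)C(C)C` has not yet been run in this assay. Its change from compound 2 is diisopropylamino in place of pyrrolidin-1-yl on a thiocarbonyl carbon. Among the compounds with values here, the only measured step that bears on this, an amine swap at the same thiocarbonyl carbon, is a 1.5-fold lower number from compound 1 to compound 2 (0.19 log units; within the scatter), which lay within the scatter. A second amine swap at the same place is therefore expected to give no step beyond the scatter, and compound 3 is expected at 1300 nM, between 500 nM and 3500 nM. The expected step from compound 2 to compound 3 is no change at the digits printed from compound 2 to compound 3 (within the scatter).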

Compound 3, half-maximal inhibitory concentration: > 25000 nM
Compound 3 gave a limit, no number; the forecaster's own chance of this, stated with the estimate: 5%; at least 19-fold (1.28 log units) between middle value and limit.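

In this assay, compound 3 is read only as a limit of the assay: the limit of > 25000 nM in this assay, at which 1 of the 3 values shown sits.

The amine on a thiocarbonyl carbon is therefore not a tolerant position for every swap, as the step of a 1.5-fold lower number from compound 1 to compound 2 (0.19 log units; within the scatter) alone had suggested. The ringless diisopropylamino group gives an at least 19-fold higher number from compound 2 to compound 3 (1.28 log units; beyond the scatter) and an at least 12-fold higher number from compound 1 to compound 3 (1.09 log units; beyond the scatter), both large, while the two ring amines, morpholin-4-yl and pyrrolidin-1-yl, remain indistinguishable.

Diisopropylamino differs from both ring amines in having no ring and in carrying branched chains, and these compounds do not separate the two features. Diethylamino would test an open chain without the branching, and piperidin-1-yl would test a larger ring, so either could show where activity is lost.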